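The source may hold more compounds than are shown below. What is called first, only, known or untested is meant among the compounds shown, and "the series" means these compounds.

Measured so far in a functional assay on the whole organism (strain Kunming) with Mus musculus as the target, with a stated time of 0.5 h, at a dose of 300 mg/kg by the intraperitoneal route; a lower number here means a stronger effect, a higher number a weaker effect of the compound at the dose given:
compound 1 `COc1cc(OC)c(OC)cc1/C=C/COC(=O)/C=C/c1ccccc1C(F)(F)F` — compound 1 gives 100%
compound 2 `COc1cc(OC)c(OC)cc1/C=C/COC(=O)/C=C/c1ccc(F)cc1` — compound 2 gives 100%

Within the data shown here, compound 2 stands level with compound 1 at the digits recorded; the only measured step, no change at the digits printed from compound 1 to compound 2 (within the scatter), stays within the scatter. Compound 3 `COc1cccc(/C=C/C(=O)OC/C=C/c2cc(OC)c(OC)cc2OC)c1` has not yet been measured. It differs from compound 2 in one place: 3-methoxyphenyl in place of 4-fluorophenyl on a double-bonded chain carbon bound to a double-bonded chain carbon. Among the measured compounds shown here, the one measured step bears on this only loosely: it exchanged one aromatic ring for another at the same place and left the read-out unchanged, so two different rings at this place both give the full effect at this dose. For the measured compounds named here, no step to 3-methoxyphenyl at this place has been measured, so the direction for compound 3 rests on the two values alone. The step of no change at the digits printed from compound 2 to compound 3 (within the scatter) is therefore expected to stay within the scatter. For compound 3 the value in this assay is estimated at 100%, within 70% to 100%.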

Compound 3, a percentage reported as activity, at one dose (the size of the read-out at that dose, not a potency): 100%
Compound 3: the middle estimate sits on the measured number at the digits printed, within the range that was stated.
By their numbers in this assay, from the lowest: compounds 1, 2 and 3 (each within the scatter of the next).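

In this assay the place on a double-bonded chain carbon bound to a double-bonded chain carbon now holds a third aromatic ring, 3-methoxyphenyl, and the read-out gives no change at the digits printed from compound 2 to compound 3 (within the scatter) and also no change at the digits printed from compound 1 to compound 3 (within the scatter) at this dose. Set against 4-fluorophenyl, this change swaps fluorine for oxygen and adds a hydrogen-bond acceptor, yet the values of these compounds remain inseparable, so three differently substituted phenyl groups are not told apart here. No available evidence bears on this result.

From the compounds shown here alone, whether an amine or a carboxylic acid on this ring would give a value apart from these remains open. Going by these compounds, it is equally open whether replacing the ring with a saturated hexyl chain would move the read-out beyond the scatter.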